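This account rests on a few compounds, and the source may have more. Where it says the series, first, only, none or still open, it means among the compounds named here.

Working notes on the solubility series.

The shared core of compound 1 `COc1ccccc1Oc1ccc2c(NCCCNCc3ccco3)ccnc2c1` carries a 2-methoxyphenoxy group, and in a physicochemical assay for solubility, with a stated time of 18 h, at pH 7.4 (a higher number here means a more soluble compound, a lower number a less soluble compound), compound 1 gives 14500 nM. Compound 2 `COc1cccc(Oc2ccc3c(NCCCNCc4cccc(OC)c4O)ccnc3c2)c1` gives 14500 nM in this assay, and compound 3 `CC(C)(C)c1ccc(Oc2ccc3c(NCCCNCc4ccco4)ccnc3c2)cc1` gives 14500 nM in this assay. Compound 1 therefore stands level with compounds 2 and 3 at the digits shown; the one counted step, no change at the digits printed from compound 1 to compound 3 (within the scatter), lies within the scatter.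

Compound 4 `FC(F)(F)c1ccc(-c2ccc3c(NCCCNCc4ccco4)ccnc3c2)cc1` is the next member. Its change from compound 1 is 4-(trifluoromethyl)phenyl in place of 2-methoxyphenoxy on an aromatic carbon. Going by the values given here, no measured step exchanges the oxygen-linked aryl for a directly attached aryl, so no step bears directly on this change. Among the compounds with values here, the only step available, no change at the digits printed from compound 1 to compound 3 (within the scatter), changes the aryl group on the oxygen and shows no movement in this assay; that step keeps the oxygen in place, so it is a weak guide here.

On that basis the expected step of a 1.6-fold lower number from compound 1 to compound 4 (0.21 log units; within the scatter) is small and is most likely to fall within the scatter, with the wider uncertainty toward lower solubility because the change goes beyond what no change at the digits printed from compound 1 to compound 3 (within the scatter) covers. Compound 4 is expected to give about 9000 nM in this assay, within a range from 2000 nM to 15000 nM.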

Compound 4, solubility: 32000 nM
For compound 4 the middle estimate is 3.6-fold (0.55 log units) below the measured one, outside the stated range (above it).
By their numbers in this assay, from the lowest: compounds 1, 2 and 3 (each within the scatter of the next); then compound 4.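

In this assay the aromatic carbon of the shared core that carries the aryl group is not silent: 4-(trifluoromethyl)phenyl in place of 2-methoxyphenoxy gives a 2.2-fold higher number from compound 1 to compound 4 (0.34 log units; beyond the scatter) and is the only step shown that lies beyond the scatter. Going by these compounds alone, the step of no change at the digits printed from compound 1 to compound 3 (within the scatter) changed the aryl group while keeping the oxygen in place, whereas the new change removes that oxygen and alters the aryl group in a single exchange, and only this combined change shows movement. The leaving group counts 2 hydrogen-bond acceptors and the entering group 0, but nothing available here accounts for the rise in number or ties it to that count or to any other feature of the two groups.

Within the data shown here, the single exchange leaves the direct aryl attachment and the trifluoromethyl group unseparated, and a plain phenyl or a 4-(trifluoromethyl)phenoxy group at the same carbon would be needed to tell them apart. Also open, going by these compounds, is how an aliphatic amine such as a morpholine or a carboxylic acid on that aryl group would read in this assay against this modest step.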